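A few compounds are considered here, and "the series" means these few. Any claim that something is new, unique, unknown or untested is made for them only; others in the source may bear on it.

Three analogues sharing one core have been measured in a functional assay on UO-31 cells (Homo sapiens) for inhibition, read by sulforhodamine B assay, with a stated time of 48 h; a higher number here means a weaker inhibitor of growth, a lower number a stronger inhibitor of growth. Compound 1 `CN1CCN(CCCOc2cccc3nc(Nc4ccc(Cl)c(C(F)(F)F)c4)ccc23)CC1` gives 1460 nM. Compound 2 `CC(C)c1ccc(Nc2ccc3c(OCCCN4CCN(C)CC4)cccc3n2)cc1` gives 12900 nM, and compound 3 `CN1CCN(CCCOc2cccc3nc(Nc4ccc(F)c(F)c4)ccc23)CC1` gives 4340 nM. Among these three numbers compound 3 stands second highest: it lies a 3.0-fold lower number from compound 2 to compound 3 (0.47 log units; beyond the scatter) and a 3.0-fold higher number from compound 1 to compound 3 (0.47 log units; beyond the scatter). Compound 4 `CN1CCN(CCCOc2cccc3nc(Nc4cc(Cl)cc(Cl)c4)ccc23)CC1` carries the change (3,5-dichlorophenyl in place of 3,4-difluorophenyl on a nitrogen on an aromatic ring). The measured steps that touch the same place are the swap of 4-chloro-3-(trifluoromethyl)phenyl for 3,4-difluorophenyl, which gave a 3.0-fold higher number from compound 1 to compound 3 (0.47 log units; beyond the scatter), and the swap of 4-isopropylphenyl for 3,4-difluorophenyl, which gave a 3.0-fold lower number from compound 2 to compound 3 (0.47 log units; beyond the scatter); both were modest. Compound 1, which bears a chlorine on that phenyl, has the lowest number of the three, so a phenyl bearing two chlorines is expected to move the number downward modestly from compound 3, giving an estimated 1.7-fold lower number from compound 3 to compound 4 (0.24 log units; within the scatter). Compound 4 is therefore estimated at 2500 nM, expected to fall between 1000 nM and 6500 nM.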

Compound 4, concentration for 50% growth inhibition: 1490 nM
Estimate against measurement, compound 4: 1.7-fold (0.22 log units) above, within the range that was stated.
By their numbers in this assay, from the lowest: compounds 1 and 4 (each within the scatter of the next); then compound 3; then compound 2.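

Measured in this assay the 3,5-dichlorophenyl group on the nitrogen gives a 2.9-fold lower number from compound 3 to compound 4 (0.46 log units; beyond the scatter) against 3,4-difluorophenyl and an 8.7-fold lower number from compound 2 to compound 4 (0.94 log units; beyond the scatter) against 4-isopropylphenyl. Against 4-chloro-3-(trifluoromethyl)phenyl it gives a 1.0-fold higher number from compound 1 to compound 4 (0.01 log units; within the scatter) and the two cannot be ordered, so the low end of this set no longer rests on that one group: a phenyl carrying chlorine but no trifluoromethyl stands there too. Nothing given here explains these differences. The compounds shown leave open whether both chlorines are needed, since a phenyl with a single chlorine is not among them. As far as these compounds go, how the number would move with bromine, methoxy or nitrile in place of those chlorines, or with an amine or a carboxylic acid on that phenyl, also remains open.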